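The source may report more compounds than this note shows. Statements on the series, on what has been measured and on what is new or still open speak of the compounds shown alone.

For the measured compounds named here, in an ADME assay on Vero cells (Chlorocebus sabaeus) for cytotoxicity, read by fluorescence, with a stated time of 4 days (a lower number here means a stronger inhibitor, a higher number a weaker inhibitor), only two compounds have numbers so far. Compound 1 `COc1cc2c(cc1OC)CN(S(=O)(=O)c1ccc(-n3cc(COc4ccccc4C(C)=O)nn3)cc1)CC2` gives 37200 nM and compound 2 `O=c1ccc2ccc(OCc3cn(-c4cccc(S(=O)(=O)N5CCc6ccccc6C5)c4)nn3)cc2o1` gives 91500 nM. Compound 1 thus holds the lower of the two numbers, and the gap between them lies beyond the usual scatter of repeated measurements.

Compound 3 `COc1cc2c(cc1OC)CN(S(=O)(=O)c1ccc(-n3cc(COc4cc(C=O)ccc4OC)nn3)cc1)CC2` keeps the core of compound 1 and differs only in the group on an oxygen on a saturated carbon: 5-formyl-2-methoxyphenyl in place of 2-acetylphenyl on an oxygen on a saturated carbon. Here 5-formyl-2-methoxyphenyl stands in place of 2-acetylphenyl.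

Going by the values given here, no pair of measured compounds differs in a single place, so the data give no direct measure of such a change in this assay. Among the compounds with values here, the only guide to scale is the pair of numbers itself, with compound 1 at 37200 nM and compound 2 at 91500 nM. A small upward move, within the scatter, is therefore expected, and the estimated change is a 1.2-fold higher number from compound 1 to compound 3 (0.08 log units; within the scatter). For compound 3 the expected value is 45000 nM, with an estimated range from 18000 nM to 110000 nM.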

Compound 3, half-maximal inhibitory concentration: > 50000 nM
Compound 3 gave a limit, no number; the forecaster's own chance of this, stated with the estimate: 20%; middle value at least 1.1-fold (0.04 log units) away from the limit.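

In this assay compound 3 gives > 50000 nM, which is a limit of the assay and not a number. For the compounds shown here, this is the first single-place comparison available, and with the shared core held fixed, 5-formyl-2-methoxyphenyl in place of 2-acetylphenyl on an oxygen on a saturated carbon gives an at least 1.3-fold higher number from compound 1 to compound 3 (0.12 log units; that floor lies within the scatter), so the floor of the step alone does not set the two compounds apart. Going by these compounds, the true size of the step therefore stays unknown, and it may lie within or beyond the scatter, because the reading for compound 3 ends at a limit: the limit of > 50000 nM in this assay, at which 1 of the 3 values shown sits.

The pair changes the carbonyl group and adds a methoxy group in one step, so the part each plays cannot be separated, and a phenyl ring carrying only a methoxy or only a formyl group would be needed to pull them apart. On these data alone, it also remains open how this place would read with an amine or a carboxylic acid on the ring, and whether the same exchange would read alike on the core of compound 2.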